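Swapping the aryl head group: from compound 3 to compound 4

The source may hold more compounds than are shown below. What is called first, only, known or untested is meant among the compounds shown, and "the series" means these compounds.

Measured compounds:
compound 1 `COc1cccc(CNc2ncnc3ccc(-c4cnn(C)c4)cc23)c1`: 36000 nM
compound 2 `Cn1cc(-c2cnc3ncnc(NCc4cccc([N+](=O)[O-])c4)c3c2)cn1`: > 100000 nM
compound 3 `Cn1cc(-c2ccc3ncnc(Nc4ccc(F)c(Cl)c4)c3c2)cn1`: 3100 nM

In a functional assay on SK-BR-3 cells (Homo sapiens) for antiproliferative activity, read by MTT assay, with a stated time of 72 h (on this read-out higher numbers stand for weaker inhibition and lower numbers for stronger inhibition), compound 3 gives 3100 nM, the lowest of the two numbers recorded; compound 1 gives 36000 nM, a gap beyond the usual scatter. For compound 2 the result is only a limit, > 100000 nM, as noted in the limit of > 100000 nM in this assay, at which 1 of the 3 values shown sits. Compound 4 `C#Cc1cccc(Nc2ncnc3ccc(-c4cnn(C)c4)cc23)c1` differs from compound 3 by 3-ethynylphenyl in place of 3-chloro-4-fluorophenyl on a nitrogen on an aromatic ring. Among the compounds with values here, no measured pair shows this exchange, so the expected change in this assay is small, within the scatter or at most a modest gain. Compound 4 is estimated at 2000 nM (range 500 nM to 10000 nM), a step of a 1.6-fold lower number from compound 3 to compound 4 (0.19 log units; within the scatter).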

Compound 4, half-maximal inhibitory concentration: 5870 nM
Beside the measured number, compound 4's estimate is 2.9-fold (0.47 log units) below it; measured number inside the range.
By their numbers in this assay, from the lowest: compounds 3 and 4 (each within the scatter of the next); then compound 1. At a limit, above all of these: compound 2.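

In this assay, putting 3-ethynylphenyl in place of 3-chloro-4-fluorophenyl on this nitrogen gives a 1.9-fold higher number from compound 3 to compound 4 (0.28 log units; within the scatter), so the two head groups cannot be told apart here. Within the data shown here, the position therefore accepts a triple bond in place of chlorine and fluorine without a step beyond the scatter, something the earlier compounds could not show. Nothing measured here accounts for this step. Still open, going by these compounds, is how this position responds to a head group carrying an amine or a carboxylic acid. The compounds shown also leave open whether a longer chain on the 3-ethynylphenyl ring would change the number.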